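Rearranging two oxygen substituents on the chalcone aryl ring

The source may hold more compounds than are shown below. What is called first, only, known or untested is meant among the compounds shown, and "the series" means these compounds.

Measured so far:
- compound 1 `Cc1ccc(S(=O)(=O)NC(=O)Nc2ccccc2C(=O)/C=C/c2ccccc2)cc1`: 25 ug/mL
- compound 2 `Cc1ccc(S(=O)(=O)NC(=O)Nc2ccccc2C(=O)/C=C/c2ccc(N(C)C)cc2)cc1`: 38.1 ug/mL
- compound 3 `COc1ccc(/C=C/C(=O)c2ccccc2NC(=O)NS(=O)(=O)c2ccc(C)cc2)c(OC)c1`: 16 ug/mL

These values come from an ADME assay on the whole organism for cytotoxicity, with Artemia salina as the target, with a stated time of 24 h; a higher number here means that more compound is needed for the effect, a lower number that less compound is needed. Compound 3 has the lowest number of the three, although a 1.6-fold lower number from compound 1 to compound 3 (0.19 log units; within the scatter) lies within the scatter; only a 2.4-fold lower number from compound 2 to compound 3 (0.38 log units; beyond the scatter) stands beyond it. Compound 4 `CCOc1cc(/C=C/C(=O)c2ccccc2NC(=O)NS(=O)(=O)c2ccc(C)cc2)ccc1O` differs from compound 3 in one place: 3-ethoxy-4-hydroxyphenyl in place of 2,4-dimethoxyphenyl on a double-bonded chain carbon bound to a double-bonded chain carbon. Within the data shown here, the steps that bear on this position, a 1.6-fold lower number from compound 1 to compound 3 (0.19 log units; within the scatter) and a 2.4-fold lower number from compound 2 to compound 3 (0.38 log units; beyond the scatter), were both small, so changes on this ring have so far moved this assay little. A change of similar size in either direction, or none beyond the scatter, is expected. Compound 4 is therefore estimated at 20 ug/mL, within 10 ug/mL to 40 ug/mL, meaning a 1.3-fold higher number from compound 3 to compound 4 (0.10 log units; within the scatter).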

Compound 4, concentration for half-maximal effect: 19.2 ug/mL
The estimate for compound 4 lay 1.0-fold (0.02 log units) above the measured number; low and high end bracket the measured number.
By their numbers in this assay, from the lowest: compounds 3, 4, 1 and 2 (each within the scatter of the next, the first and the last beyond it).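

In this assay, the swap to 3-ethoxy-4-hydroxyphenyl keeps the same atoms but adds a hydrogen-bond donor, and a 1.2-fold higher number from compound 3 to compound 4 (0.08 log units; within the scatter) shows that this rearrangement has no readable effect here. The new ring also stays within the scatter of the other two rings, with a 1.3-fold lower number from compound 1 to compound 4 (0.11 log units; within the scatter) and a 2.0-fold lower number from compound 2 to compound 4 (0.30 log units; within the scatter) as the two steps, so compound 2 stands beyond the scatter from compound 3 alone. Nothing available explains why this position tolerates the change.

From the compounds shown here alone, whether a carboxylic acid on this ring, or a longer chain in place of ethoxy, would shift the number remains open.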